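A few compounds are considered here, and "the series" means these few. Any claim that something is new, unique, unknown or untested is made for them only; others in the source may bear on it.

Measured so far in an ADME assay on CCRF-CEM cells (Homo sapiens) for cytotoxicity, with a stated time of 72 h; on this read-out higher numbers stand for weaker inhibition and lower numbers for stronger inhibition:

compound 1, `O=Cc1c(-c2ccc(Cl)cc2Cl)nc2sc(Cc3ccc(Cl)cc3)nn12`, gives 79000 nM
compound 2, `O=Cc1c(-c2ccccc2)nc2sc(Cc3ccc(Cl)cc3)nn12`, gives 22000 nM
compound 3, `N#CSc1c(-c2ccc(Cl)cc2Cl)nc2sc(Cc3ccc(Cl)cc3)nn12`, gives 46000 nM

Compound 1 and compound 3 share a core that differs in one group: cyanosulfanyl in place of formyl on an aromatic carbon. That change gave a 1.7-fold lower number from compound 1 to compound 3 (0.23 log units; within the scatter), so the two numbers cannot be told apart here.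

Compound 2 carries the change phenyl in place of 2,4-dichlorophenyl on an aromatic carbon relative to compound 1. This made a 3.6-fold lower number from compound 1 to compound 2 (0.56 log units; beyond the scatter).

Compound 4, `N#CSc1c(-c2ccccc2)nc2sc(Cc3ccc(Cl)cc3)nn12`, is not yet measured. It relates to compound 3 by phenyl in place of 2,4-dichlorophenyl on an aromatic carbon. Going by the values given here, this is the same kind of change as the one from compound 1 to compound 2, on a ring carbon next to the ring nitrogen and two ring bonds from the ring nitrogen in both cases; what differs around the place is the neighbouring ring atom, which bears a cyanosulfanyl group (3 heavy atoms) in compound 3 and a formyl group (2 heavy atoms) in compound 1.

For compound 4 in this assay a step of about a 3.5-fold lower number from compound 3 to compound 4 (0.55 log units; beyond the scatter) is expected, because the same kind of change made a 3.6-fold lower number from compound 1 to compound 2 (0.56 log units; beyond the scatter) and because compound 3 sits at 46000 nM, close to compound 1. Among the compounds with values here, only one earlier instance supports this, so the expectation is loose. Compound 4 is accordingly estimated at 13000 nM, with a plausible span from 5000 nM to 35000 nM.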

Compound 4, half-maximal inhibitory concentration: 14000 nM
For compound 4 the middle estimate is 1.1-fold (0.03 log units) below the measured one; the range from low to high includes it.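

In this assay, phenyl in place of 2,4-dichlorophenyl gave a 3.3-fold lower number from compound 3 to compound 4 (0.52 log units; beyond the scatter), so the step seen on the core bearing formyl also appears on the core bearing cyanosulfanyl: the same change on two cores in this assay, a 3.6-fold lower number (0.56 log units; beyond the scatter) from compound 1 to compound 2 and a 3.3-fold lower number (0.52 log units; beyond the scatter) from compound 3 to compound 4, 1.1-fold (0.04 log units) apart, within the scatter of two such steps. Cyanosulfanyl in place of formyl gave a 1.6-fold lower number from compound 2 to compound 4 (0.20 log units; within the scatter), leaving the two groups indistinguishable on the phenyl core, as they also are on the 2,4-dichlorophenyl core: the same change on two cores in this assay, a 1.7-fold lower number (0.23 log units; within the scatter) from compound 1 to compound 3 and a 1.6-fold lower number (0.20 log units; within the scatter) from compound 2 to compound 4, 1.1-fold (0.04 log units) apart, within the scatter of two such steps. Within these four compounds the two changes therefore carry over from one core to the other, but this rests on a single pair of steps for each change in one cell assay, and it shows neither that the same holds on other cores nor what underlies the step from 2,4-dichlorophenyl to phenyl.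

Still open, from the compounds shown here alone, is whether the step needs both chlorines, which a ring with a single chlorine or with methoxy groups in their place would test, and whether an amine or a carboxylic acid in place of formyl or cyanosulfanyl would behave as these two groups do. Going by these compounds, all four compounds share the rest of the structure, so the effect of changes elsewhere on the core remains unknown.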